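Butanediol diether series: swapping the acid-bearing aryl ring

The compounds below may be only part of what the source reports. "The series", "measured", "known", "first", "only" and "open" are said of these compounds alone.

compound 1 `Cc1c(OCCCCOc2ccc(C(=O)O)cc2F)ccc(C(=O)CC(C)C)c1O` — 1420 nM in an assay on HEK293 cells for positive allosteric modulation of metabotropic glutamate receptor 3 (Rattus norvegicus), read by thallium flux, with a stated time of 2.5 min; a higher number here means that more compound is needed for the effect, a lower number that less compound is needed
compound 2 `Cc1ccc(C(=O)O)cc1OCCCCOc1ccc(C(=O)CC(C)C)c(O)c1C` — > 10000 nM, a limit of this assay
compound 3 `Cc1ccc(C(=O)O)cc1OCCCCOc1ccc(C(=O)CC2CCCC2)c(O)c1C` — > 10000 nM, likewise a limit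

Compound 2 stands at the limit of > 10000 nM in this assay, at which 2 of the 3 values shown sit, so no number is known for it. Compound 4 `Cc1c(OCCCCOc2ccc(C(=O)O)c(Cl)c2)ccc(C(=O)CC(C)C)c1O` is not yet measured. It differs from compound 2 in 4-carboxy-3-chlorophenyl in place of 5-carboxy-2-methylphenyl on an oxygen on a saturated carbon; a carboxyl in the 4-position with a halogen beside nothing stated, which resembles the arrangement in compound 1. The measured step that bears on this swap is an at least 7.0-fold higher number from compound 1 to compound 2 (0.84 log units; beyond the scatter), a change on the same oxygen in which the 5-carboxy-2-methylphenyl ring gave the higher number. The step that the two limits leave unreadable from compound 2 to compound 3 offers nothing usable, as both ends are limits. Because the same kind of ring exchange produced an at least 7.0-fold higher number from compound 1 to compound 2 (0.84 log units; beyond the scatter), the reverse direction is expected for compound 4, with a lower number than compound 2 but with no guarantee of reaching the level of compound 1. Compound 4 is therefore estimated at 2500 nM, between 900 nM and 9000 nM, which means an expected step of an at least 4.0-fold lower number from compound 2 to compound 4 (0.60 log units; beyond the scatter).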

Compound 4, half-maximal effective concentration: 2050 nM
Estimate against measurement, compound 4: 1.2-fold (0.09 log units) above; measured number inside the range.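

On the oxygen on a saturated carbon, 4-carboxy-3-chlorophenyl in place of 5-carboxy-2-methylphenyl gives a measurable number in this assay, with an at least 4.8-fold lower number from compound 2 to compound 4 (0.68 log units; beyond the scatter). Compound 2 itself stands at a limit of the assay, > 10000 nM, and not at a number. Going by these compounds alone, compound 1 was previously the only compound with a measurable number, and 4-carboxy-3-chlorophenyl in place of 4-carboxy-2-fluorophenyl now gives a 1.4-fold higher number from compound 1 to compound 4 (0.16 log units; within the scatter), so a second halogen-bearing 4-carboxy ring reads alike with compound 1 while the 5-carboxy-2-methylphenyl ring of compound 2 goes against the two.

Open, going by these compounds, is whether the chlorine of compound 4 matters at all, which a methyl or a hydrogen in its place would test, and whether a tetrazole could stand in for the carboxylic acid. On these data alone, the step to cyclopentyl from compound 2 to compound 3 cannot be read, so that change remains untested on a ring giving a number.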